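This account rests on a few compounds, and the source may have more. Where it says the series, first, only, none or still open, it means among the compounds named here.

Three esters that share one core have been examined in an ADME assay on Vero cells (Chlorocebus sabaeus) for cytotoxicity, with a stated time of 72 h (on this read-out higher numbers stand for weaker inhibition and lower numbers for stronger inhibition), and a fourth awaits the same test. Compound 3 `CCOC(=O)c1cc(-c2cccc(OCc3ccc(F)c(F)c3)c2)on1` gives only a limit in this assay, > 128000 nM, so no exact figure places it among the others. Compound 1 `CCOC(=O)c1cc(-c2cccc(OCc3cccc(Br)c3)c2)on1` likewise returns a limit in this assay, > 128000 nM. For compound 2 `CCOC(=O)c1cc(-c2cccc(OCc3ccccc3F)c2)on1` this assay records "not determined" (no result reported), so it adds nothing to the comparison. Within the data shown here, the one single-point change between measured compounds, from compound 1 to compound 3, cannot be sized: a step that the two limits leave unreadable from compound 1 to compound 3, since both ends rest on (the limit of > 128000 nM in this assay, at which 2 of the 3 values shown sit).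

Compound 4 `CCOC(=O)c1cc(-c2cccc(OCc3ccc(F)c(F)c3F)c2)on1` differs from compound 3 by fluoro in place of hydrogen on an aromatic carbon. Among the measured compounds shown here, no measured step reports a readable size, so the expectation can only follow the two limits seen. Compound 4 is therefore expected to stay at the same ceiling, a step of roughly a step that the limit leaves unreadable from compound 3 to compound 4, meaning no movement beyond the scatter. Compound 4 is estimated at 150000 nM, within 60000 nM to 400000 nM, and most likely reported again only as a limit.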

Compound 4, half-maximal inhibitory concentration: > 128000 nM
Compound 4 ended at the assay's limit; the forecaster's own chance of this, stated with the estimate: 85%; the middle value is on the limit's open side.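

No new step can be read from compound 4 to compound 3's neighbours: compound 1, compound 3 and compound 4 all give a limit rather than a number, because each rests on the same ceiling: the limit of > 128000 nM in this assay, at which 3 of the 4 values shown sit.

On these data alone, whether any of these group changes alters the result in this assay stays open, as does the exact figure for each of the three compounds.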